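Adding an Amino Group to Two Related Cores

The source may hold more compounds than are shown below. What is called first, only, known or untested is meant among the compounds shown, and "the series" means these compounds.

Compound 1 `ClCc1ccc(Cn2cnc3c(Cl)ncnc32)cc1` gives 2450 nM in a functional assay on NCI-H23 cells (Homo sapiens) for cytotoxicity, read by sulforhodamine B assay, with a stated time of 48 h; a lower number here means a stronger inhibitor of growth, a higher number a weaker inhibitor of growth.
Compound 2 `Nc1nc(Cl)c2ncn(Cc3ccc(CCl)cc3)c2n1` gives 30200 nM in this assay.
Compound 3 `ClCc1ccccc1Cn1cnc2c(Cl)ncnc21` gives 4360 nM in this assay.

Compound 1 and compound 2 differ by one change, (amino in place of hydrogen on an aromatic carbon). That change gave a 12-fold higher number from compound 1 to compound 2 (1.09 log units; beyond the scatter), a clear weakening of growth inhibition. Compound 1 and compound 3 are built from the same atoms joined differently; the difference between the two cores is not broken down here, and their two values lie within the scatter of each other.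

Compound 4 `Nc1nc(Cl)c2ncn(Cc3ccccc3CCl)c2n1` has not yet been measured. It differs from compound 3 by amino in place of hydrogen on an aromatic carbon, the same change seen from compound 1 to compound 2. Because that earlier change gave a 12-fold higher number from compound 1 to compound 2 (1.09 log units; beyond the scatter), a weakening of similar size is expected from compound 3 to compound 4, about a 12-fold higher number from compound 3 to compound 4 (1.08 log units; beyond the scatter). Compound 4 is therefore estimated to give 52000 nM in this assay.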

Compound 4, concentration for total growth inhibition: 8910 nM
The estimate for compound 4 lay 5.8-fold (0.77 log units) above the measured number, and the stated range ends above it.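

In this assay the amino group on the core of compound 3 gives a 2.0-fold higher number from compound 3 to compound 4 (0.31 log units; beyond the scatter) and so again weakens growth inhibition, the same direction as seen on the core of compound 1. The direction carries over between these two cores, but the size of the step does not: the same change on two cores in this assay, a 12-fold higher number (1.09 log units; beyond the scatter) from compound 1 to compound 2 and a 2.0-fold higher number (0.31 log units; beyond the scatter) from compound 3 to compound 4, 6.0-fold (0.78 log units) apart, beyond the scatter of two such steps

Two cores cannot show why the size differs, or how the change would act on a third core.

The compounds shown leave open whether another group in the same place, such as a hydroxyl or a methyl group, would also weaken growth inhibition. They also leave open whether a methylamino group would behave as amino does on either core.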